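Adding a chloro to a diacetylamino compound

The source may hold more compounds than are shown below. What is called first, only, known or untested is meant among the compounds shown, and "the series" means these compounds.

- Compound 1 `Nc1ccc(-c2nc3ccccc3s2)cc1Cl`: < 1 nM
- Compound 2 `CC(=O)Nc1ccc(-c2nc3ccccc3[nH]2)cc1`: > 10000 nM
- Compound 3 `CC(=O)N(C(C)=O)c1ccc(-c2nc3ccccc3s2)cc1`: > 100 nM

All three results come from a functional assay on MDA-MB-468 cells (Homo sapiens) for antiproliferative activity (a lower number here means a stronger inhibitor, a higher number a weaker inhibitor), and each one is a limit of the assay rather than an exact number. Compound 3 stands at the limit of > 100 nM in this assay, at which 1 of the 3 values shown sits, so its true value is not known.

Compound 4 `CC(=O)N(C(C)=O)c1ccc(-c2nc3ccccc3s2)cc1Cl` differs from compound 3 by a single change: chloro in place of hydrogen on an aromatic carbon. Within the data shown here, no measured pair of compounds shows this change alone, so any forecast is uncertain. Compound 1 also carries a chloro, and its limit is < 1 nM. On that basis, a move toward stronger inhibition, beyond the usual scatter, is expected in this assay. The expected step is an at least 3.3-fold lower number from compound 3 to compound 4 (0.52 log units; beyond the scatter). For compound 4 the estimated value is 30 nM, with an expected range from 1 nM to 1000 nM.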

Compound 4, half-maximal inhibitory concentration: > 1000 nM
Compound 4 ended at the assay's limit; the forecaster's own chance of this, stated with the estimate: 35%; middle value at least 33-fold (1.52 log units) away from the limit.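

In this assay compound 4 gives > 1000 nM and this number is a limit of the assay, not an exact value. With the chloro held in place, diacetylamino in place of amino gives an at least 1000-fold higher number from compound 1 to compound 4 (3.00 log units; beyond the scatter) in the same assay, so on this core a chloro ortho to a diacetylamino group does not bring back the strength seen with the free amino group of compound 1. On these data alone, the step between compound 3 and compound 4 cannot be read, as both numbers are limits, and the effect of the chloro itself remains unknown.

Still open, as far as these compounds go, is how the amino compound without the chloro would compare with compound 1. Also open, from the compounds shown here alone, is whether a fluoro or a methyl at the same place would behave like the chloro.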